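A few compounds are considered here, and "the series" means these few. Any claim that something is new, unique, unknown or untested is made for them only; others in the source may bear on it.

Compound 2 `CC(C)c1noc(-c2ccc(C3=NCCN3)cc2)n1`: 230 nM
Compound 3 `COc1ccc(-c2noc(-c3ccc(C4=NCCN4)cc3)n2)cc1OC`: 756 nM
Compound 1 `N#Cc1ccc(C2=NCCN2c2ccc(C(F)(F)F)cn2)cc1`: 41800 nM

All three were tested in an assay for inhibition of Amine oxidase [flavin-containing] B (Homo sapiens), read by fluorescence and spectrophotometry, using microsomes, with stated times of 30 min and 20 min; on this read-out lower numbers stand for stronger inhibition and higher numbers for weaker inhibition. Compound 2 gives the lowest number of the three; the nearest is compound 3, whose number is higher by a step beyond the scatter, and compound 1 lies far higher still. Compound 4 `Clc1ccc(-c2noc(-c3ccc(C4=NCCN4)cc3)n2)cc1Cl` has not yet been measured. It differs from compound 2 in one place: 3,4-dichlorophenyl in place of isopropyl on an aromatic carbon. Within the data shown here, no measured pair shows this exact step. Compound 3 also carries an aromatic ring on the shared core and gives 756 nM, so a modest rise from compound 2 is expected. The expected step is a 1.7-fold higher number from compound 2 to compound 4 (0.24 log units; within the scatter), likely within or near the scatter. Compound 4 is expected to give 400 nM, ranging from 120 nM to 1500 nM.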

Compound 4, half-maximal inhibitory concentration: 12 nM
The estimate for compound 4 lay 33-fold (1.52 log units) above the measured number, and the stated range ends above it.
By their numbers in this assay, from the lowest: compound 4; then compound 2; then compound 3; then compound 1.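

Putting 3,4-dichlorophenyl in place of isopropyl gives a 19-fold lower number from compound 2 to compound 4 (1.28 log units; beyond the scatter) in this assay and shows that this position on the five-membered aromatic ring accepts a much larger group with a gain in inhibition. An aromatic ring here does not settle the outcome alone, since compound 3 gives 756 nM with a differently substituted ring in the same place, so what the ring carries matters. Nothing available explains the size of this gain. Still open, on these data alone, is whether a single chlorine would do as well, and how a phenyl ring carrying an amine or a carboxylic acid would read.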